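Changing the Ester Group and Its Effect on Cytotoxicity

The compounds below may be only part of what the source reports. "The series", "measured", "known", "first", "only" and "open" are said of these compounds alone.

Compound 1, `CCCCCCCC(=O)OCCc1c(-c2ccccc2Cl)c2cc(Cl)ccc2[nH]c1=O`, gives 78000 nM in an ADME assay on HepG2 2.2.15 cells (Homo sapiens) for cytotoxicity; on this read-out lower numbers stand for higher toxicity in this test and higher numbers for lower toxicity in this test.
Compound 2, `O=C(OCCc1c(-c2ccccc2Cl)c2cc(Cl)ccc2[nH]c1=O)c1cccs1`, reaches only > 1700000 nM in this assay, which is a limit of the assay and not a number.
Compound 3, `O=C(OCCc1c(-c2ccccc2Cl)c2cc(Cl)ccc2[nH]c1=O)c1ccco1`, gives 98000 nM in this assay.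

Among the two values that are numbers, compound 3 stands highest, but its nearest neighbour is close: a 1.3-fold higher number from compound 1 to compound 3 (0.10 log units; within the scatter). The third value is a limit (the limit of > 1700000 nM in this assay, at which 1 of the 3 values shown sits).

The step under study leads from compound 3 to compound 4, `O=C(/C=C/c1cccc(C(F)(F)F)c1)OCCc1c(-c2ccccc2Cl)c2cc(Cl)ccc2[nH]c1=O`. The change is 2-(3-(trifluoromethyl)phenyl)ethenyl in place of furan-2-yl on a carbonyl carbon.

Three measured steps exchange the group on this carbonyl carbon. The exchange of heptyl for furan-2-yl moved little: a 1.3-fold higher number from compound 1 to compound 3 (0.10 log units; within the scatter). The exchanges involving thiophen-2-yl were large: an at least 21-fold higher number from compound 1 to compound 2 (1.33 log units; beyond the scatter) and an at least 17-fold lower number from compound 2 to compound 3 (1.23 log units; beyond the scatter). None of them brings in an aryl-substituted ethenyl group, so the direction for compound 4 is open, and a step within the scatter is expected as the most likely outcome, with a wide range to cover the large swings seen with thiophen-2-yl.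

Compound 4 is therefore expected to give 80000 nM in this assay, with a range from 20000 nM to 400000 nM. The expected step is estimated as a 1.2-fold lower number from compound 3 to compound 4 (0.09 log units; within the scatter).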

Compound 4, half-maximal cytotoxic concentration: > 1400000 nM
Compound 4: only a limit was reported; the forecaster's own chance of this, stated with the estimate: 25%; middle value at least 17-fold (1.24 log units) from the limit.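

On this carbonyl carbon, 2-(3-(trifluoromethyl)phenyl)ethenyl joins thiophen-2-yl as a second group tied to a large rise in this assay, with an at least 14-fold higher number from compound 3 to compound 4 (1.15 log units; beyond the scatter) and an at least 17-fold higher number from compound 1 to compound 4 (1.25 log units; beyond the scatter), so such a rise no longer rests on thiophen-2-yl alone. The value of compound 4 is a limit of the assay and not a number: the limit of > 1400000 nM in this assay, at which 1 of the 4 values shown sits. Compound 2 also stands at a limit of the assay, and the step that joins it to compound 4 cannot be read: the limit of > 1700000 nM in this assay, at which 1 of the 4 values shown sits.

An aromatic ring in the ester group does not by itself go with the large rise, as compound 3 carries furan-2-yl and goes against that pattern, and the compounds shown do not tell whether the double bond, the phenyl ring or the trifluoromethyl group matters most in compound 4. Also open, on these data alone, is how this assay would respond to a plain phenyl group on this carbonyl carbon, or to a ring that carries an amine or a carboxylic acid in place of trifluoromethyl.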